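Compound 3 to compound 4: bromo for dimethylamino

The source may report more compounds than this note shows. Statements on the series, on what has been measured and on what is new or still open speak of the compounds shown alone.

Measured so far in an ADME assay on Vero cells (Chlorocebus sabaeus) for inhibition; a lower number here means that less compound is tolerated, a higher number that more compound is tolerated (half-maximal cytotoxic concentration):
compound 1 `O=C1/C(=C/c2ccccc2Cl)CCC/C1=C\c1ccccc1Cl` gives 30600 nM
compound 2 `O=C1/C(=C/c2cccc(Br)c2)CCC/C1=C\c1cccc(Br)c1` gives 35900 nM
compound 3 `COc1ccc(/C=C2\CCC/C(=C\c3ccc(N(C)C)cc3)C2=O)cc1` gives 392000 nM

Compound 3 is the highest of the three, and its gaps to compound 2 and compound 1 both lie beyond the scatter. Compound 1 and compound 2 lie within the scatter of each other. The next compound is compound 4 `COc1ccc(/C=C2\CCC/C(=C\c3ccc(Br)cc3)C2=O)cc1`, which differs from compound 3 in one place: bromo in place of dimethylamino on an aromatic carbon, para to a large group (bromo in place of dimethylamino on an aromatic carbon).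

Among the compounds with values here, no two measured compounds differ in one place, so the size of this step can only be read indirectly. The nearest guide is compound 2, which carries bromo and no dimethylamino and gives 35900 nM in this assay. Compound 4 keeps the methoxy group of compound 3, which compound 1 and compound 2 lack, so the expectation stops short of their level without reaching back to compound 3. The expected step of a 4.4-fold lower number from compound 3 to compound 4 (0.64 log units; beyond the scatter) is downward and beyond the scatter. The estimate for compound 4 is 90000 nM (expected range 35000 nM to 250000 nM).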

Compound 4, half-maximal cytotoxic concentration: 250000 nM
Compound 4: middle estimate off by 2.8-fold (0.44 log units), on the low side; the range from low to high includes it.
By their numbers in this assay, from the lowest: compounds 1 and 2 (each within the scatter of the next); then compounds 4 and 3 (each within the scatter of the next).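

Within the data shown here, this is the only step so far that changes a single place. In this assay the change gives a 1.6-fold lower number from compound 3 to compound 4 (0.20 log units; within the scatter) and so leaves the read-out where it was, even though three heavy atoms including a nitrogen leave and a single bromine enters on this aromatic carbon. Dimethylamino is therefore not required at this position to keep the number at the level of compound 3, and bromo serves equally well there in this read-out. No measurement on these compounds bears on why the two groups read alike.

Among these compounds, only two groups have been read at this carbon, so it remains open whether a carboxylic acid or a primary amine there would leave the number equally unmoved. The methoxy group, kept in both compound 3 and compound 4, also remains unassessed, and the other differences among the compounds cannot be read as single steps, so the contribution of each remains unassigned.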